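Moving a methyl across the anilino ring of a glutarimide isoindolinedione

A few compounds are considered here, and "the series" means these few. Any claim that something is new, unique, unknown or untested is made for them only; others in the source may bear on it.

Compound 1 `Cc1ccccc1Nc1ccc2c(c1)C(=O)N(C1CCC(=O)NC1=O)C2=O` has the lowest number of the three measured compounds in an assay on FRT-Jurkat cells for inhibition of nuclear factor NF-kappa-B complex (Homo sapiens), read by flow cytometry, with a stated time of 24 h, tested at 10 uM (a lower number here means less inhibition, a higher number more inhibition at the concentration tested (going by the name of the read-out)), giving 2%. Compound 2 `CCCc1ccc(Nc2cccc3c2C(=O)N(C2CCC(=O)NC2=O)C3=O)cc1` gives 23% and compound 3 `CC(C)(C)c1ccc(Nc2cccc3c2C(=O)N(C2CCC(=O)NC2=O)C3=O)cc1` gives 36%; both carry a substituent on the anilino ring, and both stand beyond the scatter above compound 1. For the measured compounds named here, the only single-change step available, a number 13 percentage points higher from compound 2 to compound 3 (beyond the scatter), concerns the size of such a substituent rather than its placement, so it bears on the present question only loosely.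

Compound 4 `Cc1ccc(Nc2ccc3c(c2)C(=O)N(C2CCC(=O)NC2=O)C3=O)cc1` differs from compound 1 as follows: 4-methylphenyl in place of 2-methylphenyl on a nitrogen on an aromatic ring. Going by the values given here, no measured pair shows this exact change. What the numbers do show is that compounds 2 and 3, whose methyl-bearing positions resemble that of compound 4, sit well above compound 1, which is the one 2-methylphenyl case. On that basis a modest rise is expected, a number 13 percentage points higher from compound 1 to compound 4 (beyond the scatter), with wide uncertainty. Compound 4 is estimated at 15%, within the range 0% to 35%.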

Compound 4, a percentage reported as inhibition, at one concentration (the size of the read-out at that concentration, not a potency): 5%
The estimate for compound 4 lay 10 percentage points above the measured number, within the range that was stated.
By their numbers in this assay, from the lowest: compounds 1 and 4 (each within the scatter of the next); then compound 2; then compound 3.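

In this assay the exchange of 2-methylphenyl for 4-methylphenyl gives a number 3 percentage points higher from compound 1 to compound 4 (within the scatter), so on this core the two placements of the methyl cannot be told apart. The higher numbers of compound 2 and compound 3 do not carry over to compound 4, which differs from each of them in more than one place. No measurement shown here accounts for this result.

From the compounds shown here alone, it remains open whether propyl or tert-butyl in place of the methyl of compound 4 would give a higher number on this core. Also open, going by these compounds, is how a polar group such as a carboxylic acid or a dimethylamino group in place of that methyl would read in this assay.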